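The source may hold more compounds than are shown below. What is called first, only, known or untested is meant among the compounds shown, and "the series" means these compounds.

Measured compounds in a functional assay on HCT-15 cells (Homo sapiens) for inhibition, read by sulforhodamine B assay, with a stated time of 48 h; a lower number here means a stronger inhibitor of growth, a higher number a weaker inhibitor of growth:
compound 1 `COc1cc(-c2nn(-c3cccc(NC(=O)Nc4cc(C(F)(F)F)cc(C(F)(F)F)c4)c3)cc2-c2ccncc2)ccc1Cl`, giving 1640 nM;
compound 2 `COc1cc(-c2nn(-c3cccc(NC(=O)Nc4ccc(Cl)c(Cl)c4)c3)cc2-c2ccncc2)ccc1Cl`, for which this assay reports only a limit, > 50000 nM;
compound 3 `O=C(Nc1cccc(-n2cc(-c3ccncc3)c(-c3ccc(Cl)c(O)c3)n2)c1)Nc1ccc(Cl)c(Cl)c1`, giving 29600 nM.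

Compound 2 thus stands at the limit of > 50000 nM in this assay, at which 1 of the 3 values shown sits, with no number of its own; among the three compounds, only compound 1 and compound 3 carry actual values, and compound 1 shows the lower one. Compound 4 `COc1cc(-c2nn(-c3cccc(NC(=O)c4ccccc4)c3)cc2-c2ccncc2)ccc1Cl` differs from compound 2 by phenyl in place of (3,4-dichlorophenyl)amino on a carbonyl carbon, so the urea linkage of compound 2 becomes a simple benzamide without the two chlorines. Within the data shown here, no measured step covers this change. Among the measured compounds shown here, the only measured step, an at least 1.6-fold lower number from compound 2 to compound 3 (0.22 log units; that floor lies within the scatter), alters the oxygen substituent on the other end of the molecule and says nothing about the amide end. With compound 2 already at the limit and the change removing the substituted aryl amine that compound 1 and compound 3 share, compound 4 is expected to remain weak, and the expected step of a number no higher from compound 2 to compound 4 (the limit leaves the size open) is essentially none that can be read against a limit. The estimate for compound 4 in this assay is 50000 nM, within 15000 nM to 150000 nM.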

Compound 4, concentration for total growth inhibition: > 100000 nM
Compound 4 ended at the assay's limit (the forecaster's own chance of this, stated with the estimate: 70%); middle value at least 2.0-fold (0.30 log units) away from the limit.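

In this assay, among these compounds, compound 2 and compound 4 each carry only a limit and no number of their own, so no step between them can be read. The compounds shown leave open whether phenyl in place of (3,4-dichlorophenyl)amino on a carbonyl carbon strengthens, weakens or leaves unchanged the inhibition of growth.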